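Methyl position on the biaryl arm of compound 2

This account rests on a few compounds, and the source may have more. Where it says the series, first, only, none or still open, it means among the compounds named here.

Measured compounds in this assay:
compound 1 `Oc1ccccc1CNc1ccc(N2CCCC2)cc1`: "not active" (no number reported)
compound 2 `Cc1ccc(-c2ccc(NCc3ccccc3O)cc2)cc1`: 3790 nM

Among the compounds with values here, in a functional assay on Jurkat cells (Homo sapiens) for activation, with a stated time of 24 h (on this read-out higher numbers stand for an effect only at larger amounts of compound and lower numbers for an effect already at smaller amounts), compound 2 gives 3790 nM and is the only compound with a number. Compound 1 gives "not active" (no number reported) in this assay, without a number. Compound 3 `Cc1cccc(-c2ccc(NCc3ccccc3O)cc2)c1` is compound 2 with 3-methylphenyl in place of 4-methylphenyl on an aromatic carbon. Within the data shown here, no step between measured compounds is known, so nothing in the data points to a change beyond the scatter in either direction. Compound 3 is expected at 4000 nM, with a range of 1500 nM to 12000 nM. The expected step of a 1.1-fold higher number from compound 2 to compound 3 (0.02 log units; within the scatter) stays within the scatter.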

Compound 3, half-maximal effective concentration: 9190 nM
The estimate for compound 3 lay 2.3-fold (0.36 log units) below the measured number; the range from low to high includes it.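

In this assay, the step of a 2.4-fold higher number from compound 2 to compound 3 (0.38 log units; beyond the scatter) shows that the placement of the methyl on the biaryl arm matters, even though the leaving and entering groups have the same atoms. On this read-out, 4-methylphenyl compares favourably with 3-methylphenyl, though the step is modest. The data offer no explanation for this difference. From the compounds shown here alone, it remains open whether unsubstituted phenyl, or a methoxy, amine or carboxylic acid group on this ring, would improve on compound 2. Going by these compounds, whether the same placement preference holds for groups other than methyl also remains open.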